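A few compounds are considered here, and "the series" means these few. Any claim that something is new, unique, unknown or untested is made for them only; others in the source may bear on it.

Values in a physicochemical assay for solubility, in phosphate buffer, at pH 7.4 (on this read-out lower numbers stand for lower solubility and higher numbers for higher solubility), so far

compound 1 `COc1ccc(NC(=O)C(=O)c2cn(C(C)C)c3ccccc23)cn1` gives 20000 nM
compound 2 `COc1ccc(NC(=O)C(=O)c2cc(C(C)C)n3ccccc23)cn1` gives 10000 nM
compound 3 `COCCn1cc(C(=O)C(=O)Nc2ccc(OC(C)C)nc2)c2ccccc21` gives 10000 nM
compound 4 `COCC(C)(C)n1cc(C(=O)C(=O)Nc2ccc(OC)nc2)c2ccccc21` is not yet measured

Compound 1 lies within the scatter of both compound 2 and compound 3, so these data cannot separate the three numbers. Among the compounds with values here, no two measured compounds differ in one place only, which leaves the series without a direct step to lean on.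

Compound 4 keeps the core of compound 1 and alters one group, with isopropyl becoming 1-(methoxymethyl)-1-methylethyl. The change is methoxymethyl in place of hydrogen on a saturated chain carbon bound to an aromatic nitrogen and two saturated chain carbons.

In this assay no step beyond the scatter is expected, with only a slight lean towards a lower number. The grounds are thin: the three measured compounds sit in a narrow band, and compound 3 gives 10000 nM while differing from compound 1 in more than one place. The step of a 1.7-fold lower number from compound 1 to compound 4 (0.22 log units; within the scatter) is expected to stay inside the scatter. For compound 4 an estimated 12000 nM is expected, with 4000 nM to 30000 nM as the expected range.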

Compound 4, solubility: 10000 nM
Estimate against measurement, compound 4: 1.2-fold (0.08 log units) above; the range from low to high includes it.
By their numbers in this assay, from the lowest: compounds 2, 3, 4 and 1 (each within the scatter of the next).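

In this assay, within the data shown here, the change from isopropyl to 1-(methoxymethyl)-1-methylethyl gives the only direct step so far, a 2.0-fold lower number from compound 1 to compound 4 (0.30 log units; within the scatter). Where the earlier compounds allowed no comparison in one place, this pair shows that methoxymethyl can take the place of hydrogen on a saturated chain carbon bound to an aromatic nitrogen and two saturated chain carbons without a step that can be told from the scatter. No measurement at hand speaks to a reason for this result.

This is one change on the core of compound 1, so it does not establish how far this position tolerates change in general, and it sets no trend. Still open, as far as these compounds go, is whether an amine such as dimethylaminomethyl, a carboxylic acid such as carboxymethyl, or a longer ether chain such as ethoxymethyl in the same place would leave the number within the scatter of compound 1 or produce a step beyond it.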